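Acetylation of an Aryl Amine on a Sulfonylhydrazone Core

The compounds below may be only part of what the source reports. "The series", "measured", "known", "first", "only" and "open" are said of these compounds alone.

Measured compounds:
compound 1 `Cc1ccc(N)cc1S(=O)(=O)N(C)/N=C/c1cnn2ccc(C#N)cc12` — > 1000 nM
compound 2 `CCc1ccc([N+](=O)[O-])cc1S(=O)(=O)N(C)/N=C/c1cnn2ccc(C#N)cc12` — 280 nM

Of the compounds shown here, two sharing the same core have been tested in an assay on isolated protein for inhibition of phosphatidylinositol 4,5-bisphosphate 3-kinase catalytic subunit beta isoform (Homo sapiens), read by 33P incorporation, with a stated time of 60 min; on this read-out lower numbers stand for stronger inhibition and higher numbers for weaker inhibition. For compound 1 the result is a limit of the assay rather than a number, given as > 1000 nM. Compound 2 gives 280 nM in this assay. These two compounds differ in more than one place, so their values are compared only as they stand: compound 1 sits at the limit, compound 2 gives a number.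

Where compound 1 stands is fixed only by the limit of > 1000 nM in this assay, at which 1 of the 2 values shown sits, so its true value is not known beyond that point.

Compound 3 `CC(=O)Nc1ccc(C)c(S(=O)(=O)N(C)/N=C/c2cnn3ccc(C#N)cc23)c1` has not yet been measured in this assay. It differs from compound 1 by acetyl in place of hydrogen on a nitrogen on an aromatic ring. No step between measured compounds resembles this change, so there is no shown step to lean on. Compound 3 is expected to gain somewhat on compound 1, with the step that the limit leaves unreadable from compound 1 to compound 3, but the expectation is loose. Compound 3 is estimated at 1500 nM, within 300 nM to 8000 nM, and a limit instead of a number remains a real possibility.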

Compound 3, half-maximal inhibitory concentration: > 1000 nM
Compound 3 ended at the assay's limit (the forecaster's own chance of this, stated with the estimate: 50%); the middle value is on the limit's open side.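

In this assay compound 3 gives > 1000 nM, which is a limit of the assay and not a number. Compound 1 also stands at a limit, so no step can be read between compound 1 and compound 3: the limit of > 1000 nM in this assay, at which 2 of the 3 values shown sit. The compounds shown leave open whether acetyl in place of hydrogen on the aromatic amine nitrogen changes inhibition at all, and in which direction.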